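Swapping hydroxy for amino at the benzylic carbon

A few compounds are considered here, and "the series" means these few. Any claim that something is new, unique, unknown or untested is made for them only; others in the source may bear on it.

Of the compounds shown here, three have been tested in an assay for inhibition of 15-hydroxyprostaglandin dehydrogenase [NAD(+)] (Homo sapiens), read by fluorescence, with a stated time of 15 min, in the presence of a further agent that is not named here; a higher number here means a weaker inhibitor, a lower number a stronger inhibitor. Compound 1 `CCCC[S+]([O-])c1sc2nc(-c3ncco3)cc(-c3ccccc3)c2c1N` gives 1.4 nM. Compound 2 `CCC[S+]([O-])c1sc2ncccc2c1N`, which lacks the two rings attached to the shared core, gives 151 nM. Compound 3 `CCCC[S+]([O-])c1sc2nc(-c3nccs3)cc(-c3ccc(CO)cc3)c2c1N` gives 2.5 nM; this lies within the scatter of compound 1, and far beyond the scatter from compound 2, whose number is much higher. Compound 4 `CCCC[S+]([O-])c1sc2nc(-c3nccs3)cc(-c3ccc(CN)cc3)c2c1N` is still to be measured in this assay. It differs from compound 3 by amino in place of hydroxy on a saturated chain carbon bound to an aromatic carbon. Within the data shown here, with no measured pair showing this change, the expected step of a 1.2-fold higher number from compound 3 to compound 4 (0.08 log units; within the scatter) is small, within the scatter, in no clear direction. Compound 4 is therefore estimated at 3 nM, with a range from 1 nM to 10 nM.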

Compound 4, half-maximal inhibitory concentration: 11.5 nM
The estimate for compound 4 lay 3.8-fold (0.58 log units) below the measured number; measured number above the stated range.
By their numbers in this assay, from the lowest: compounds 1 and 3 (each within the scatter of the next); then compound 4; then compound 2.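

In this assay, amino in place of hydroxy on a saturated chain carbon bound to an aromatic carbon gives a 4.6-fold higher number from compound 3 to compound 4 (0.66 log units; beyond the scatter) and so lies beyond the usual scatter. Although the step is modest, this position clearly responds to the exchange of a single heavy atom, with hydroxymethyl the better of the two groups here. The data offer no explanation for this difference. The compounds shown leave open how a carboxylic acid or a methoxy group would read in place of the hydroxy. They also leave open whether a longer chain carrying the amino group would differ from aminomethyl.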